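The compounds below may be only part of what the source reports. "The series", "measured", "known", "first", "only" and "open" are said of these compounds alone.

Measured so far:
Compound 1, `CCCCCCCN1CCC(C(=O)Nc2cc(Cl)c(N)cc2OC)CC1`, in a functional assay on the whole organism for antagonist activity, with Mus musculus as the target (on this read-out higher numbers stand for an effect only at larger amounts of compound and lower numbers for an effect already at smaller amounts), gives > 10 mg/kg, a limit of the assay rather than a number.
Compound 2, `CCCCN1CCC(C(=O)Nc2cc(Cl)c(N)cc2OC)CC1`, gives > 10 mg/kg, again a limit.
Compound 3, `COc1cc(N)c(Cl)cc1NC(=O)C1CCN(Cc2ccc(OCc3ccccc3)cc2)CC1`, gives > 4 mg/kg, also a limit.

Compound 2 thus stands only at a limit in this assay, at the limit of > 10 mg/kg in this assay, at which 2 of the 3 values shown sit. Compound 4, `COc1cc(N)c(Cl)cc1NC(=O)C1CCN(Cc2ccccc2F)CC1`, differs from compound 2 by 2-fluorophenyl in place of propyl on a saturated chain carbon bound to an amine nitrogen in a ring. Among the measured compounds shown here, the one measured step, a step that the two limits leave unreadable from compound 1 to compound 2, is left unreadable by its two limits, and compound 3 sits at the limit of > 4 mg/kg in this assay, at which 1 of the 3 values shown sits. For the measured compounds named here, no step bears on the change, so no direction and no size beyond the scatter can be foreseen. Compound 4 is therefore expected to remain near its limit, estimated at 10 mg/kg within 3 mg/kg to 30 mg/kg. The expected step is a number no higher from compound 2 to compound 4 (the limit leaves the size open).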

Compound 4, dose for half-maximal effect: > 4 mg/kg
Compound 4 ended at the assay's limit (the forecaster's own chance of this, stated with the estimate: 70%); the middle value is on the limit's open side.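

Among the compounds shown here, compound 1, compound 2 and compound 4 all stand at limits rather than numbers in this assay, so no step among them can be read. The compounds shown leave open at what dose any of them reaches half-maximal effect, and whether the group on the amine nitrogen in the ring matters.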